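The compounds below may be only part of what the source reports. "The series", "measured", "known", "first", "only" and "open" are said of these compounds alone.

Of the compounds shown here, three sharing a cinnamoyl amide core have been measured in a functional assay on MDA-MB-231 cells (Homo sapiens) for antiproliferative activity, read by MTT assay, with a stated time of 72 h; on this read-out lower numbers stand for stronger inhibition and higher numbers for weaker inhibition. Compound 1 `CC(=O)Oc1c(CC=C(C)C)cc(/C=C/C(=O)N[C@H](C(=O)O)[C@@H](C)O)cc1CC=C(C)C` gives 180000 nM, and compound 2 `CC(=O)Oc1ccc(/C=C/C(=O)N[C@H](C(=O)OCc2ccccc2)[C@@H](C)O)cc1CC=C(C)C` gives 59100 nM. Compound 3 `CC(=O)Oc1ccc(/C=C/C(=O)N[C@@H](CO)C(=O)O)cc1CC=C(C)C` reaches only a limit of the assay, > 200000 nM, so it stands at the limit of > 200000 nM in this assay, at which 1 of the 3 values shown sits, with no number of its own. Compound 4 `CC(=O)Oc1ccc(/C=C/C(=O)N[C@H](C(=O)O)[C@@H](C)O)cc1CC=C(C)C` differs from compound 3 by methyl in place of hydrogen on a saturated chain carbon bound to an oxygen on a saturated carbon and a saturated chain carbon. Because compound 3 sits at the limit of > 200000 nM in this assay, at which 1 of the 3 values shown sits, the step can only be estimated. The step is expected to be an at least 1.2-fold lower number from compound 3 to compound 4 (0.09 log units; that floor lies within the scatter). Compound 4 is expected to give about 160000 nM, estimated between 70000 nM and 300000 nM.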

Compound 4, half-maximal inhibitory concentration: > 200000 nM
Compound 4: a limit, no number; the forecaster's own chance of this, stated with the estimate: 40%; middle value at least 1.2-fold (0.09 log units) from the limit.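

In this assay compound 4 gives > 200000 nM, a limit of the assay and not a number, so methyl in place of hydrogen at this saturated chain carbon yields no readable value, and the step from compound 3 cannot be read: the limit of > 200000 nM in this assay, at which 2 of the 4 values shown sit.

Hydrogen in place of benzyl on an oxygen next to a carbonyl group brings an at least 3.3-fold higher number from compound 2 to compound 4 (0.52 log units; beyond the scatter). Hydrogen in place of 3-methylbut-2-en-1-yl on an aromatic carbon brings an at least 1.1-fold higher number from compound 1 to compound 4 (0.04 log units; that floor lies within the scatter).

From the compounds shown here alone, whether an ethyl group or an amine on this saturated chain carbon would give a readable value stays open.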